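Swapping a ring for a methyl on compound 1

A few compounds are considered here, and "the series" means these few. Any claim that something is new, unique, unknown or untested is made for them only; others in the source may bear on it.

Among the compounds with values here, in an ADME assay on MDCK cells (Canis lupus familiaris) for permeability, read by LC-MS, with a stated time of 90 min, tested at 2 uM (a higher number here means that the compound crosses the layer faster, a lower number that the compound crosses the layer more slowly), compound 1 `Cc1cc(C)c(CN2CCc3c(Cl)cc([C@H](CO)[C@H]4CCCO4)c(Cl)c3C2=O)c(=O)[nH]1` gives 4.1 10^-6 cm/s as its one reading, and it is the only one of the three measured compounds with a single number. Compound 2 `COC(c1cc(Cl)c2c(c1Cl)C(=O)N(Cc1c(C)cc(C)[nH]c1=O)CC2)C1CCN(C2COC2)CC1` has two readings at 7 10^-6 cm/s; 7.9 10^-6 cm/s (2 entries) and compound 3 `CCOC(c1cc(Cl)c2c(c1Cl)C(=O)N(Cc1c(C)cc(C)[nH]c1=O)CC2)C1CS(=O)(=O)C1` has two at 12 10^-6 cm/s; 7.7 10^-6 cm/s (2 entries) on structures of their own. Compound 4 `Cc1cc(C)c(CN2CCc3c(Cl)cc([C@@H](C)CO)c(Cl)c3C2=O)c(=O)[nH]1` keeps the core of compound 1 and changes one group (methyl in place of oxolan-2-yl on a saturated chain carbon bound to an aromatic carbon and a saturated chain carbon): methyl in place of oxolan-2-yl on a saturated chain carbon bound to an aromatic carbon and a saturated chain carbon. Within the data shown here, no measured pair differs in one place only, so the size of this step in this assay is a judgement. A small rise no larger than the usual scatter is expected (a 1.5-fold higher number from compound 1 to compound 4 (0.17 log units; within the scatter)). The estimate for compound 4 is 6 10^-6 cm/s (expected range 2.5 10^-6 cm/s to 14 10^-6 cm/s).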

Compound 4, apparent permeability: 15 10^-6 cm/s
Compound 4: the middle estimate sits 2.5-fold (0.40 log units) below what was measured; measured number above the stated range.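

Within the data shown here, this is the first change in one place only, so it gives the first direct reading of this position: with methyl in place of oxolan-2-yl on the saturated chain carbon, this assay shows a 3.7-fold higher number from compound 1 to compound 4 (0.56 log units; beyond the scatter). Repeat entries of a single compound lie closer together than this step, as seen for compound 2: the several entries of compound 2 in this assay, 7 10^-6 cm/s; 7.9 10^-6 cm/s (2 entries). Compound 3 shows the same: the several entries of compound 3 in this assay, 12 10^-6 cm/s; 7.7 10^-6 cm/s (2 entries).

One step cannot separate the loss of the ring from the loss of its oxygen. A cyclopentyl ring or an ethyl group at this place could begin to tell these apart.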